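This account rests on a few compounds, and the source may have more. Where it says the series, first, only, none or still open, it means among the compounds named here.

The series rests on a shared core carrying two benzyloxy groups. Compound 1 `O=C1O/C(=C\Cn2cc(-c3ccc(Br)cc3)nn2)C(OCc2ccccc2)=C1OCc1ccccc1` holds an unsaturated linker to the triazole. In a functional assay on HCT-116 cells (Homo sapiens) for antiproliferative activity, read by MTT assay, with a stated time of 72 h (on this read-out higher numbers stand for weaker inhibition and lower numbers for stronger inhibition), compound 1 gives > 100000 nM, which is a limit of the assay and not a number. Compound 1 thus sits at the limit of > 100000 nM in this assay, at which 1 of the 2 values shown sits. Within the data shown here, compound 2 `O=C1O[C@H]([C@@H](O)Cn2cc(-c3ccc(Br)cc3)nn2)C(OCc2ccccc2)=C1OCc1ccccc1` instead bears a saturated, hydroxylated linker; in this assay compound 2 gives 9420 nM, the only numerical value recorded here. Among the measured compounds shown here, no step between measured compounds is available for comparison.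

Compound 3 `O=C1O[C@H]([C@@H](O)Cn2cc(-c3cc(F)cc(F)c3)nn2)C(OCc2ccccc2)=C1OCc1ccccc1` differs from compound 2 in one place: 3,5-difluorophenyl in place of 4-bromophenyl on an aromatic carbon. For the measured compounds named here, with no measured step of this kind to lean on, the expected step from compound 2 to compound 3 is estimated at a 1.6-fold higher number from compound 2 to compound 3 (0.20 log units; within the scatter), a mild weakening that may not exceed the usual scatter. In this assay compound 3 is accordingly expected to give about 15000 nM, within a range from 5000 nM to 50000 nM.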

Compound 3, half-maximal inhibitory concentration: 48200 nM
Compound 3: middle estimate off by 3.2-fold (0.51 log units), on the low side; the range from low to high includes it.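

Among these compounds, with the saturated, hydroxylated linker held constant, this aromatic carbon of the five-membered ring gives the first single change that can be read in this assay: 3,5-difluorophenyl in place of 4-bromophenyl brings a 5.1-fold higher number from compound 2 to compound 3 (0.71 log units; beyond the scatter). The aryl group at this place therefore bears on the read-out, and here the exchange weakens inhibition by a modest but real margin, although this one pair sets no trend. Nothing given here accounts for the size or direction of this step.

Because the bromine leaves and the two fluorines enter in the same step, the compounds shown do not tell which of these changes carries the weakening. A plain phenyl or a 4-chlorophenyl at this place would help to separate the two.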